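The source may hold more compounds than are shown below. What is called first, only, known or untested is meant among the compounds shown, and "the series" means these compounds.

Measured compounds in a functional assay on MCF7 cells (Homo sapiens) for cytotoxicity, with a stated time of 48 h; on this read-out higher numbers stand for weaker inhibition and lower numbers for stronger inhibition:
compound 1 `O=[N+]([O-])c1ccc(CN2CCC(n3cc(CC(OCc4cc(-c5ccccc5)no4)c4ccc(Br)cc4)nn3)CC2)cc1` sits at the assay limit, > 25000 nM.
compound 2 `O=[N+]([O-])c1ccc(CN2CCC(n3cc(CC(OCc4cc(-c5ccc(F)cc5)no4)c4ccc(Br)cc4)nn3)CC2)cc1` gives 7000 nM.
compound 3 `COc1ccc(-c2cc(COC(Cc3cn(C4CCN(Cc5ccc([N+](=O)[O-])cc5)CC4)nn3)c3ccc(Br)cc3)on2)cc1` gives 4000 nM.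

Compound 3 holds the lowest of the two numbers; its nearest neighbour is compound 2, and a 1.8-fold lower number from compound 2 to compound 3 (0.24 log units; within the scatter) lies within the scatter, so no order between the two is claimed. Compound 1 contributes only a limit (the limit of > 25000 nM in this assay, at which 1 of the 3 values shown sits). Compound 4 `N#Cc1cccc(-c2cc(COC(Cc3cn(C4CCN(Cc5ccc([N+](=O)[O-])cc5)CC4)nn3)c3ccc(Br)cc3)on2)c1` carries 3-cyanophenyl in place of 4-methoxyphenyl on an aromatic carbon. The measured steps both start from hydrogen, an at least 3.5-fold lower number from compound 1 to compound 2 (0.55 log units; beyond the scatter) and an at least 6.2-fold lower number from compound 1 to compound 3 (0.79 log units; beyond the scatter), and neither covers a nitrile group. Going by the values given here, no step therefore bears directly on this change, and only a small step is expected in this assay, a 1.5-fold higher number from compound 3 to compound 4 (0.18 log units; within the scatter), direction uncertain. Compound 4 is estimated at 6000 nM, between 2000 nM and 20000 nM.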

Compound 4, half-maximal inhibitory concentration: 2000 nM
Compound 4: middle estimate off by 3.0-fold (0.48 log units), on the high side, and the stated range covers the measured number.
By their numbers in this assay, from the lowest: compounds 4, 3 and 2 (each within the scatter of the next, the first and the last beyond it). At a limit, above all of these: compound 1.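

In this assay, the aromatic carbon next to the ring nitrogen accepts 3-cyanophenyl as well as 4-methoxyphenyl, with a 2.0-fold lower number from compound 3 to compound 4 (0.30 log units; within the scatter), so no order between the two is claimed. Against 4-fluorophenyl the same group gives a readable difference, a 3.5-fold lower number from compound 2 to compound 4 (0.54 log units; beyond the scatter). Compound 1 is a limit, so an at least 12-fold lower number from compound 1 to compound 4 (1.09 log units; beyond the scatter) is only a bound: the limit of > 25000 nM in this assay, at which 1 of the 4 values shown sits.

Going by these compounds, whether the nitrile or its placement on the phenyl ring decides the outcome stays open, as 4-cyanophenyl and 3-methoxyphenyl would be needed to separate them. What an amine or a carboxylic acid on that ring would give is also unknown.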